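Isopropoxy in place of chloro: notes on the series

The source may report more compounds than this note shows. Statements on the series, on what has been measured and on what is new or still open speak of the compounds shown alone.

Measured so far in a functional assay on the whole organism (strain Sprague-Dawley) for inhibition, with Rattus norvegicus as the target, with a stated time of 10 min; a higher number here means that more compound is needed for the effect, a lower number that less compound is needed:
- compound 1 `O=C(O)c1cnc(-c2ccccc2Cl)[nH]c1=O`: 5 mg/kg
- compound 2 `Nc1ccccc1-c1ncc(C(=O)O)c(=O)[nH]1`: 50 mg/kg
- compound 3 `COc1ccccc1-c1ncc(C(=O)O)c(=O)[nH]1`: 10 mg/kg

Compound 1 sits at the low end of these three numbers, but it is not clearly separated from every other compound. The nearest step is a 2.0-fold higher number from compound 1 to compound 3 (0.30 log units; within the scatter). The furthest is a 10-fold higher number from compound 1 to compound 2 (1.00 log units; beyond the scatter).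

Next in line is compound 4 `CC(C)Oc1ccccc1-c1ncc(C(=O)O)c(=O)[nH]1`, still unmeasured. The change is isopropoxy in place of chloro on an aromatic carbon, ortho to a large group.

For the measured compounds named here, the closest precedent is the methoxy swap, a 2.0-fold higher number from compound 1 to compound 3 (0.30 log units; within the scatter), since it also places an oxygen-linked group at this carbon. The amino swap, a 10-fold higher number from compound 1 to compound 2 (1.00 log units; beyond the scatter), and the related 5.0-fold lower number from compound 2 to compound 3 (0.70 log units; beyond the scatter) show that this place can produce a modest step in this assay, but both involve amino, which compound 4 does not carry. No group as large as isopropoxy has been measured here, so the range must stay wide.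

On these data alone, on the methoxy precedent, no step beyond the scatter is expected, and the direction remains open. The expected step is a 1.2-fold higher number from compound 1 to compound 4 (0.08 log units; within the scatter). Compound 4 is expected at 6 mg/kg. The estimated range for compound 4 runs from 2 mg/kg to 20 mg/kg.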

Compound 4, dose for 50% inhibition: 0.8 mg/kg
Beside the measured number, compound 4's estimate is 7.5-fold (0.88 log units) above it; measured number below the stated range.
By their numbers in this assay, from the lowest: compound 4; then compounds 1 and 3 (each within the scatter of the next); then compound 2.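

In this assay, an oxygen-linked group at this aromatic carbon no longer simply matches chloro: methoxy stayed within the scatter of it, whereas isopropoxy gives a 6.3-fold lower number from compound 1 to compound 4 (0.80 log units; beyond the scatter). For the compounds shown here, with the oxygen kept in place, isopropyl in place of methyl gives a 13-fold lower number from compound 3 to compound 4 (1.10 log units; beyond the scatter), so the group carried on that oxygen can by itself produce a large step here, something the earlier compounds gave no sign of. The span at this carbon also widens, with isopropoxy in place of amino giving a 63-fold lower number from compound 2 to compound 4 (1.80 log units; beyond the scatter), and compound 4 now holds the lowest number of the four, with each of its steps to the other three beyond the scatter.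

No measurement at hand bears on why isopropoxy lowers the number in this way. On these data alone, with only methyl and isopropyl on the oxygen, two points fix no trend, so it remains open whether ethyl, cyclopropyl, tert-butyl or a longer chain there would lower the number further or reverse the step, and whether any such gain carries over to the other open carbons of the same aromatic ring.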